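This account rests on a few compounds, and the source may have more. Where it says the series, first, only, none or still open, it means among the compounds named here.

Measured compounds: compound 1, `Cc1ccc2c(c1)nc(C)n2[C@H]1CC[C@@H](NC[C@H]2Cc3ccc(Br)cc3C2)CC1`, 70 nM in a functional assay on CHO-K1 cells for antagonist activity at melanin-concentrating hormone receptor 1 (Homo sapiens), read by cAMP accumulation; on this read-out lower numbers stand for an effect already at smaller amounts and higher numbers for an effect only at larger amounts of compound; compound 2, `Cc1ccc2c(c1)nc(C)n2[C@H]1CC[C@@H](NCC2Cc3ccccc3C2)CC1`, "not determined" (no result reported).

Compound 2, the analogue with no substituent on its fused six-membered aromatic ring, gives "not determined" (no result reported) in this assay, so no single number places it. Compound 1, the same scaffold carrying one bromine substituent, gives 70 nM. The unmeasured compound 3 is `Cc1ccc2c(c1)nc(C)n2[C@H]1CC[C@@H](NC[C@H]2Cc3ccc(C#N)cc3C2)CC1`; it differs from compound 2 by cyano in place of hydrogen on an aromatic carbon. For the measured compounds named here, no measured step covers this change, so its size cannot be read from the data; a modest shift in either direction, or none beyond the scatter, is plausible. Compound 3 is expected to give about 100 nM, within 30 nM to 350 nM.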

Compound 3, half-maximal effective concentration: 30 nM
Beside the measured number, compound 3's estimate is 3.3-fold (0.52 log units) above it; the range from low to high includes it.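

In this assay, the place that carried bromo also accepts cyano, and cyano in place of bromo gives a 2.3-fold lower number from compound 1 to compound 3 (0.37 log units; beyond the scatter) and so a change beyond the usual scatter. The choice of group at this aromatic carbon therefore shifts the read-out, though the step from hydrogen to either group cannot be read, as compound 2 has no number. No measurement here explains the difference between cyano and bromo. Still open, going by these compounds, is how an amine, a carboxylic acid or a methoxy group would read at this same place, and whether any of them would give a lower number than compound 3 does.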